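Amide variation at the carbonyl of the shared core

The source may report more compounds than this note shows. Statements on the series, on what has been measured and on what is new or still open speak of the compounds shown alone.

Compound 1 `Cn1ncc2cc(-c3cnccc3/C=C/C(=O)N3CCOCC3)ccc21` stands lowest of the two numbers recorded in an assay on a protein complex for inhibition of CDK8/Cyclin C (Homo sapiens), with a stated time of 1 h, tested at 10 uM; a higher number here means more inhibition at the concentration tested (going by the name of the read-out), a lower number less inhibition: compound 1 gives 95%, while the gap to compound 2 lies within the scatter. Compound 2 `O=C(/C=C/c1ccncc1-c1ccc2ccccc2c1)NC1CC1` gives 102% in this assay, so the numbers of both measured compounds lie level with each other, within the scatter. Compound 3 `CNC(=O)/C=C/c1ccncc1-c1ccc2c(cnn2C)c1` has not been measured; it differs from compound 1 by methylamino in place of morpholin-4-yl on a carbonyl carbon. For the measured compounds named here, with no comparable step recorded, the change a number 5 percentage points lower from compound 1 to compound 3 (within the scatter) is expected to stay within the scatter, with no direction claimed. Compound 3 is estimated at 90% in this assay, in the range 70% to 102%.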

Compound 3, a percentage reported as inhibition, at one concentration (the size of the read-out at that concentration, not a potency): 98%
Beside the measured number, compound 3's estimate is 8 percentage points below it; low and high end bracket the measured number.
By their numbers in this assay, from the lowest: compounds 1, 3 and 2 (each within the scatter of the next).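

In this assay, for the compounds shown here, methylamino in place of morpholin-4-yl on the carbonyl carbon gives a number 3 percentage points higher from compound 1 to compound 3 (within the scatter) and is the first single-place step read at this position. The six-membered ring and its hydrogen-bond acceptor can therefore give way to methylamino and its hydrogen-bond donor with no change beyond the scatter. Nothing available explains this outcome.

A single-concentration read-out leaves any potency difference between compound 1 and compound 3 open. Also open, from the compounds shown here alone, is whether a carboxylic acid or a longer alkylamine chain at this carbonyl carbon would hold the same level.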